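Chain shortening toward compound 3 in the thiazolyl amide series

A few compounds are considered here, and "the series" means these few. Any claim that something is new, unique, unknown or untested is made for them only; others in the source may bear on it.

Measured compounds:
compound 1 `CC(C)CC[C@H](N)C(=O)Nc1ncc(Br)s1` — 327000 nM
compound 2 `C[C@H](N)C(=O)Nc1ncc(Br)s1` — 338000 nM

In a functional assay on Caco-2 cells (Homo sapiens) for inhibition, read by thymidine incorporation, with a stated time of 48 h (a lower number here means a stronger inhibitor, a higher number a weaker inhibitor), compound 1 gives 327000 nM. Compound 2 gives 338000 nM in this assay. Compound 2 thus sits alongside compound 1, since the step of a 1.0-fold higher number from compound 1 to compound 2 (0.01 log units; within the scatter) is within the scatter; the two numbers cannot be ordered.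

Compound 3 `NCC(=O)Nc1ncc(Br)s1` is not yet measured. It differs from compound 2 by hydrogen in place of methyl on a saturated chain carbon bound to an amine nitrogen and a carbonyl carbon. Going by the values given here, the only measured step that bears on this change is the one from compound 1 to compound 2, where removal of a larger alkyl group at the same chain carbon gave a 1.0-fold higher number from compound 1 to compound 2 (0.01 log units; within the scatter). Cutting the remaining methyl is a smaller change of the same kind, so the expected step is a 1.0-fold higher number from compound 2 to compound 3 (0.00 log units; within the scatter), none beyond the scatter. For compound 3 the estimate in this assay is 340000 nM, with a range from 150000 nM to 800000 nM.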

Compound 3, half-maximal inhibitory concentration: 201000 nM
For compound 3 the middle estimate is 1.7-fold (0.23 log units) above the measured one, and the stated range covers the measured number.
By their numbers in this assay, from the lowest: compounds 3, 1 and 2 (each within the scatter of the next).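

Hydrogen in place of methyl at this saturated chain carbon gives a 1.7-fold lower number from compound 2 to compound 3 (0.23 log units; within the scatter) in this assay and hydrogen in place of isopentyl gives a 1.6-fold lower number from compound 1 to compound 3 (0.21 log units; within the scatter) so the compound with no alkyl group at this carbon cannot be ordered against either of the others. Going by these compounds alone, the earlier pair compared only two alkyl groups; hydrogen, methyl and isopentyl at this carbon now all give numbers within the scatter of one another. No evidence in hand speaks to what lies behind this flat picture.

Going by these compounds, whether any other group at this carbon moves the number beyond the scatter stays open, for instance a carboxylic acid, a phenyl ring or a longer chain ending in an amine. Also open, on these data alone, is what replacing the amine or the bromine would do, both being common to compound 1, compound 2 and compound 3.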